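Swapping a Sulfonylpiperidine for a Diethylaminopropyl Chain

This account rests on a few compounds, and the source may have more. Where it says the series, first, only, none or still open, it means among the compounds named here.

Compound 1, `Cc1ccccc1-c1nn(-c2ccc(F)cc2F)cc1CNC1CCN(S(C)(=O)=O)CC1`, was tested in an ADME assay on Huh-7 cells (Homo sapiens) for cytotoxicity; on this read-out lower numbers stand for higher toxicity in this test and higher numbers for lower toxicity in this test. In this assay compound 1 gives > 20000 nM, which is a limit of the test rather than a measured number. Two related compounds were run in the same test. Compound 2, `COc1ccc(-n2cc(CNCCN3CCN(C)CC3)c(-c3ccccc3C)n2)cc1`, gives > 20000 nM in this assay, again a limit. Compound 3, `CN1CCN(CCNCc2cn(-c3ccc(F)cc3F)nc2-c2ccc(S(=O)(=O)N(C)C)cc2)CC1`, gives > 20000 nM in this assay, also a limit. Within the data shown here, all that can be said of the three is the limit of > 20000 nM in this assay, at which 3 of the 3 values shown sit; none of them reached a level of toxicity the test could put a number on, and so no step between them can be sized.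

Compound 4, `CCN(CC)CCCNCc1cn(-c2ccc(F)cc2F)nc1-c1ccccc1C`, has not yet been measured. It differs from compound 1 in one place: 3-(diethylamino)propyl in place of 1-(methylsulfonyl)piperidin-4-yl on an amine nitrogen. Among the measured compounds shown here, no measured pair of compounds shows how large a change of this kind might be, so there is no direct guide. Because the limit of > 20000 nM in this assay, at which 3 of the 3 values shown sit, describes every measured compound, the step from the parent to the new compound is expected to be a number no higher from compound 1 to compound 4 (the limit leaves the size open), which means no change beyond the usual scatter. Compound 4 is therefore expected to give about 20000 nM, within a range from 8000 nM to 50000 nM, and quite possibly once more only a limit.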

Compound 4, half-maximal cytotoxic concentration: > 20000 nM
Compound 4: a limit, no number (the forecaster's own chance of this, stated with the estimate: 70%); the middle value lies on the limit itself.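

In this assay compound 4 gives > 20000 nM, which is a limit and not a number. Compound 1 and compound 4 both stand at a limit, and the size of the step between them cannot be read. The compounds shown leave open which change, if any, would bring toxicity this test can put a number on, for all share one result: the limit of > 20000 nM in this assay, at which 4 of the 4 values shown sit.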